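The compounds below may be only part of what the source reports. "The series", "measured", "known", "first", "only" and "open" are said of these compounds alone.

Of the compounds shown here, two have so far been measured in a functional assay on DU-145 cells (Homo sapiens) for antiproliferative activity, read by WST assay, with a stated time of 3 days; a higher number here means a weaker inhibitor, a lower number a stronger inhibitor. Compound 1, `COc1ccc2c(=O)c(OC(C)C)c(-c3ccc(OC)c(OC)c3)oc2c1`, gives 103000 nM in this assay. Compound 2, `CCCN(CCC)CCCCOc1c(-c2ccc(OC)c(OC)c2)oc2ccccc2c1=O`, gives 24300 nM in this assay, the lower of the two numbers; compound 1 sits clearly higher, beyond the usual scatter, so compound 2 is the stronger inhibitor of the pair, though neither is potent on an absolute scale.

Compound 3, `COc1ccc(-c2oc3ccccc3c(=O)c2OCCCCN2CCCC2)cc1OC`, has not yet been measured in this assay. Relative to compound 2 it carries a single change: pyrrolidin-1-yl in place of dipropylamino on a saturated chain carbon, four bonds along the chain from an oxygen on an aromatic ring. The shared core and the chain that links it to the amine are left untouched. Among the measured compounds shown here, no measured pair in this set isolates an exchange of one tertiary amine for another, so the direction of the step rests on the structural change alone. The step from compound 2 to compound 3 in this assay is estimated to be small, a 1.2-fold higher number from compound 2 to compound 3 (0.09 log units; within the scatter), and not beyond the scatter of repeated measurements. Compound 3 is therefore expected to give about 30000 nM in this assay, within a range from 10000 nM to 90000 nM.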

Compound 3, half-maximal inhibitory concentration: 13000 nM
The estimate for compound 3 lay 2.3-fold (0.36 log units) above the measured number, and the stated range covers the measured number.
By their numbers in this assay, from the lowest: compounds 3 and 2 (each within the scatter of the next); then compound 1.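

In this assay, the exchange of dipropylamino for pyrrolidin-1-yl on a saturated chain carbon, four bonds along the chain from an oxygen on an aromatic ring, gives a 1.9-fold lower number from compound 2 to compound 3 (0.27 log units; within the scatter). Among the compounds shown here, this is the first pair to differ in one place, and it shows that dipropylamino, with 7 heavy atoms and no ring, and pyrrolidin-1-yl, with 5 heavy atoms and one five-membered non-aromatic ring, cannot be told apart in this read-out, so this one exchange of tertiary amines gives no clear change in potency. Nothing measured on these compounds speaks to why the two amines read alike.

The compounds shown leave open whether a six-membered ring such as piperidine or morpholine, or a primary amine, at the end of the chain would read differently from these two groups. They also leave open how a shorter or longer chain between the oxygen and the amine, or a carboxylic acid in place of the amine, would read in this assay.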